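Shortening the Side Chain of a Non-Cytotoxic Analogue

A few compounds are considered here, and "the series" means these few. Any claim that something is new, unique, unknown or untested is made for them only; others in the source may bear on it.

Compound 2 `CCCCCCc1cc2cn(COCCO)c(O)nc-2n1` carries a hexyl chain on its core. In a functional assay on HEL cells (Homo sapiens) (a lower number here means that less compound is tolerated, a higher number that more compound is tolerated), compound 2 gives > 200000 nM, which is a limit of the assay rather than a measured number. Two other compounds share the same picture. In this assay compound 1 `CCCCCC#Cc1cc2cn(COCCO)c(=O)nc2o1` gives > 50000 nM, again only a limit. In this assay compound 3 `O=c1nc2occc2cn1COCCO` gives > 200000 nM, once more a limit. Going by the values given here, the one step that can be drawn between them, a step that the two limits leave unreadable from compound 1 to compound 3, therefore has no readable size.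

Compound 4 `CCCCc1cc2cn(COCCO)c(O)nc-2n1` is the next analogue to be tested. It differs from compound 2 by hydrogen in place of ethyl on a saturated chain carbon, four bonds along the chain from an aromatic carbon. Among the compounds with values here, no measured step speaks directly to this change, since the only comparison that exists is unreadable. Within the data shown here, what the set does show is the limit of > 200000 nM in this assay, at which 2 of the 3 values shown sit, and the limit of > 50000 nM in this assay, at which 1 of the 3 values shown sits: every compound so far sits at a limit, and compound 2 itself stands at the higher of the two. With nothing pointing either way, no step beyond the scatter is expected in this assay, and a number no higher from compound 2 to compound 4 (the limit leaves the size open) is the expected outcome. Compound 4 is accordingly estimated at 200000 nM in this assay, within a range from 60000 nM to 600000 nM, most likely reported once again as a limit.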

Compound 4, half-maximal cytotoxic concentration: > 200000 nM
Compound 4 was reported as a limit (the forecaster's own chance of this, stated with the estimate: 80%); the middle value sits exactly at the limit.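

In this assay compound 4 gives > 200000 nM, which is a limit of the assay. Compound 2 also stands at a limit, so no step can be read between compound 2 and compound 4. The compounds shown leave open what concentration of either compound would prove cytotoxic, and whether shortening the chain changes it.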